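The source may report more compounds than this note shows. Statements on the series, on what has been measured and on what is new or still open speak of the compounds shown alone.

In a functional assay on OVCAR-8 cells (Homo sapiens) (a lower number here means a stronger inhibitor of growth, a higher number a weaker inhibitor of growth), compound 1 (`O=S(=O)(/C=C/c1ccc(Cl)c(Cl)c1)Cc1ccc(Nc2ncnc3ccc(Br)cc23)cc1`) gives 100 nM and compound 2 (`O=S(=O)(/C=C/c1ccc(Cl)cc1)Cc1ccc(Nc2ncnc3ccc(Br)cc23)cc1`) gives 3000 nM as the higher of the two numbers, which makes compound 2 the weaker inhibitor of the pair. Compound 3 (`O=S(=O)(/C=C/c1ccc(C(F)(F)F)cc1F)Cc1ccc(Nc2ncnc3ccc(Br)cc23)cc1`) departs from compound 2 by this change: 2-fluoro-4-(trifluoromethyl)phenyl in place of 4-chlorophenyl on a double-bonded chain carbon bound to a double-bonded chain carbon with 2-fluoro-4-(trifluoromethyl)phenyl in place of 4-chlorophenyl on a double-bonded chain carbon bound to a double-bonded chain carbon. For the measured compounds named here, the only measured step is a 30-fold higher number from compound 1 to compound 2 (1.48 log units; beyond the scatter) with hydrogen in place of chloro on an aromatic carbon. Going by the values given here, this large step bears on the change only indirectly, since it concerns the same aromatic ring but no measured compound carries fluoro or trifluoromethyl. With a single pair as a guide, a moderate move toward a lower number in this assay is expected, smaller than that measured step and with wide uncertainty. The expected step is a 3.8-fold lower number from compound 2 to compound 3 (0.57 log units; beyond the scatter) as an estimate only. For compound 3 the estimated value is 800 nM with an expected range from 150 nM to 4000 nM on present evidence.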

Compound 3, concentration for 50% growth inhibition: 15000 nM
Compound 3: the middle estimate sits 19-fold (1.27 log units) below what was measured; measured number above the stated range.
By their numbers in this assay, from the lowest: compound 1; then compound 2; then compound 3.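

In this assay, placing 2-fluoro-4-(trifluoromethyl)phenyl in place of 4-chlorophenyl on a double-bonded chain carbon bound to a double-bonded chain carbon gives a 5.0-fold higher number from compound 2 to compound 3 (0.70 log units; beyond the scatter), so this replacement weakens growth inhibition in the series. Measured against 3,4-dichlorophenyl at the same place, the same group gives a 150-fold higher number from compound 1 to compound 3 (2.18 log units; beyond the scatter), which leaves the 3,4-dichlorophenyl of compound 1 as the strongest of the three aryl groups shown here. All three compounds carry halogen on this ring, yet their numbers differ well beyond the scatter, so halogen on the ring does not by itself secure strong inhibition at this position.

No measured data on these compounds bear on the reason for this loss. On these data alone, the fluoro and trifluoromethyl groups enter together, so their separate contributions remain open, as does the outcome of placing a methoxy group, a nitrile, an amine or a carboxylic acid on this ring in place of the halogens.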